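A Fluoronitrophenyl Exchange Awaiting Its Cytotoxicity Read-out

A few compounds are considered here, and "the series" means these few. Any claim that something is new, unique, unknown or untested is made for them only; others in the source may bear on it.

Compound 1, `Nc1nc(N)c(CCCN(Cc2ccc(NC(CCC(=O)O)C(=O)O)cc2)c2ccc([N+](=O)[O-])c(F)c2F)c(O)n1`, gives > 100000 nM, a limit of the assay.
Compound 2, `Nc1nc(N)c(CCCN(Cc2ccc(NC(CCC(=O)O)C(=O)O)cc2)c2cc(F)ccc2[N+](=O)[O-])c(O)n1`, gives > 100000 nM, also a limit.
Compound 3, `COC(=O)c1ccc(CN(CCCc2c(N)nc(N)nc2O)c2ccc([N+](=O)[O-])c(F)c2F)cc1`, gives 45000 nM.

All three were tested in a functional assay on CCRF-CEM cells (Homo sapiens) for cytotoxicity, in the absence of a further agent; on this read-out lower numbers stand for stronger inhibition and higher numbers for weaker inhibition. Compound 1 and compound 2 share one core, and they differ by a single change: 5-fluoro-2-nitrophenyl in place of 2,3-difluoro-4-nitrophenyl on an amine nitrogen. The step between them is a step that the two limits leave unreadable from compound 1 to compound 2, and it cannot be read because of the limit of > 100000 nM in this assay, at which 2 of the 3 values shown sit. Among the compounds with values here, compound 3 carries a different core, and how it differs from compound 1 is counted as methoxycarbonyl in place of (1,3-dicarboxypropyl)amino on an aromatic carbon; that step is an at least 2.2-fold lower number from compound 1 to compound 3 (0.34 log units; beyond the scatter), and compound 3 is the only compound of the three for which this assay reports a number rather than a limit.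

Compound 4, `COC(=O)c1ccc(CN(CCCc2c(N)nc(N)nc2O)c2cc(F)ccc2[N+](=O)[O-])cc1`, has not yet been measured. Within the data shown here, it differs from compound 3 by 5-fluoro-2-nitrophenyl in place of 2,3-difluoro-4-nitrophenyl on an amine nitrogen, which is the same change, at the same kind of place, as the one between compound 1 and compound 2. Among the measured compounds shown here, that earlier pair gives no readable size for the step, so the only anchor is the number for compound 3. The step from compound 3 to compound 4 is therefore expected to be small, a 1.1-fold higher number from compound 3 to compound 4 (0.05 log units; within the scatter), and compound 4 is estimated to give 50000 nM, most likely between 15000 nM and 150000 nM.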

Compound 4, half-maximal inhibitory concentration: 43000 nM
Estimate against measurement, compound 4: 1.2-fold (0.07 log units) above; the range from low to high includes it.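

In this assay, the exchange of 2,3-difluoro-4-nitrophenyl for 5-fluoro-2-nitrophenyl on an amine nitrogen now has one readable size, a 1.0-fold lower number from compound 3 to compound 4 (0.02 log units; within the scatter), so on the core shared by these two compounds the exchange makes no difference that stands out from ordinary repeat variation. Whether that result carries over to the core of compound 1 remains unshown, because neither compound on that core gives a number and the step there cannot be read: the limit of > 100000 nM in this assay, at which 2 of the 4 values shown sit. The other change, methoxycarbonyl in place of (1,3-dicarboxypropyl)amino, can be followed on both fluoronitrophenyl groups, with the new pair giving an at least 2.3-fold lower number from compound 2 to compound 4 (0.36 log units; beyond the scatter), so its direction repeats while its true size stays undefined: the same change on two cores in this assay, an at least 2.2-fold lower number (0.34 log units; beyond the scatter) from compound 1 to compound 3 and an at least 2.3-fold lower number (0.36 log units; beyond the scatter) from compound 2 to compound 4; the limit leaves it open whether they differ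

Still open, going by these compounds, is whether a single carboxylic acid in place of methoxycarbonyl would give a number close to those of compound 3 and compound 4 or would instead reach the limit seen with (1,3-dicarboxypropyl)amino. Also open, on these data alone, is what a nitrophenyl group carrying no fluorine, an aminophenyl group in place of the nitrophenyl group, or a longer chain on the amine nitrogen would do in this assay.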